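Tetrabromobenzotriazoles with a short hydroxylated side chain

The source may hold more compounds than are shown below. What is called first, only, known or untested is meant among the compounds shown, and "the series" means these compounds.

Measured so far:
- compound 1, `C[C@H](O)CCn1nc2c(Br)c(Br)c(Br)c(Br)c2n1`: 92%
- compound 2, `OC(CCn1nc2c(Br)c(Br)c(Br)c(Br)c2n1)c1ccc(Cl)cc1`: 93%

Both compounds share the same tetrabrominated core and differ only in the chain carried on the ring nitrogen. In a functional assay on CCRF-CEM cells (Homo sapiens) for antiproliferative activity, read by MTT assay, with a stated time of 48 h, tested at 12.5 uM (a lower number here means a stronger effect, a higher number a weaker effect of the compound at the concentration tested), compound 1 gives 92%, and compound 2 gives 93%. The two numbers sit within the usual scatter of each other, so nothing can be said about an order between them; both are at the weak end of what this read-out can show, with most of the cell growth remaining at the tested concentration.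

Compound 3, `OCC(O)Cn1nc2c(Br)c(Br)c(Br)c(Br)c2n1`, has not yet been measured in this assay. It keeps the shared core and changes only the side chain: 1,2-dihydroxyethyl in place of 2-hydroxypropyl on a saturated chain carbon bound to an aromatic nitrogen. Within the data shown here, since no measured pair in this set changes the chain in a comparable way, there is no direct guide to how large such a step is. Both measured chains already carry a single hydroxyl and give nearly full remaining growth, so the expectation is that a second hydroxyl leaves the read-out where it is, with a step of a number 2 percentage points higher from compound 1 to compound 3 (within the scatter) that stays inside the scatter. Compound 3 is therefore estimated at 94%, with a likely range from 85% to 102%.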

Compound 3, a percentage reported as activity, at one concentration (the size of the read-out at that concentration, not a potency): 60%
For compound 3 the middle estimate is 34 percentage points above the measured one; the measured number lies below the stated range.
By their numbers in this assay, from the lowest: compound 3; then compounds 1 and 2 (each within the scatter of the next).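

In this assay, the chain on the shared core proves able to move the read-out: 1,2-dihydroxyethyl in place of 2-hydroxypropyl gives a large step, a number 32 percentage points lower from compound 1 to compound 3 (beyond the scatter). The change is small on paper, since both chains have 4 heavy atoms, no ring and no net charge, and they differ in one carbon traded for an oxygen, in the count of 2 hydrogen-bond donors and 2 acceptors against 1 of each, and in the defined stereocentre of the leaving chain, so even a swap of this size at this place, on a saturated chain carbon bound to an aromatic nitrogen, can matter. Nothing available explains why the read-out moves with this change.

The compounds shown do not separate the parts of the swap, so the step could belong to the second hydroxyl, to the loss of the terminal methyl, or to both together. Also open, on these data alone, is how the read-out would respond to a longer chain carrying two hydroxyls, or to an amine or a carboxylic acid at the end of the chain.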